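Swapping methylsulfanyl for methylsulfonyl on the weakest compound

This account rests on a few compounds, and the source may have more. Where it says the series, first, only, none or still open, it means among the compounds named here.

So far three compounds have been read in a functional assay on HEp-2 cells (Homo sapiens) for cytotoxicity (on this read-out lower numbers stand for stronger inhibition and higher numbers for weaker inhibition), as the only read-out for this series. Compound 1 `Nc1nc(O)c2nnn(C3O[C@H](CO)[C@@H](O)[C@H]3O)c2n1` gives 2000 nM and compound 2 `CSc1nc(SC)c2nn([C@@H]3O[C@H](COC(C)=O)[C@@H](OC(C)=O)[C@H]3OC(C)=O)nc2n1` gives 800 nM on this measure. Compound 3 `CSc1nc(N)c2nn(C3O[C@H](CO)[C@@H](O)[C@H]3O)nc2n1` gives 25000 nM as the highest number of the three. Both other compounds lie below compound 3 by more than the scatter, so compound 3 is the weakest inhibitor measured in the series.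

The next compound is compound 4 `CS(=O)(=O)c1nc(N)c2nn(C3O[C@H](CO)[C@@H](O)[C@H]3O)nc2n1`, which has methylsulfonyl in place of methylsulfanyl on an aromatic carbon and is otherwise the same as compound 3. For the measured compounds named here, no measured pair differs in one place only, so this change has no direct precedent. Going by the values given here, the only guide is the wide spread of values, from compound 2 at 800 nM to compound 3 at 25000 nM in this assay as it stands. A moderate move towards a lower number is expected, though a result within the scatter remains possible. The expected size of the change is a 2.1-fold lower number from compound 3 to compound 4 (0.32 log units; beyond the scatter) on this estimate. For compound 4 the estimated value is 12000 nM with an expected range of 3000 nM to 50000 nM for now.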

Compound 4, half-maximal inhibitory concentration: 22000 nM
For compound 4 the middle estimate is 1.8-fold (0.26 log units) below the measured one, within the range that was stated.
By their numbers in this assay, from the lowest: compound 2; then compound 1; then compounds 4 and 3 (each within the scatter of the next).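

In this assay, for the compounds shown here, the first single-place step reads a 1.1-fold lower number from compound 3 to compound 4 (0.06 log units; within the scatter), so methylsulfonyl in place of methylsulfanyl on this aromatic carbon, between two ring nitrogen atoms, leaves the read-out unchanged within the scatter. The position thus accepts a change from 2 heavy atoms to 4 heavy atoms, and from 1 hydrogen-bond acceptor to 2 hydrogen-bond acceptors, with no measurable effect on this read-out in this pair. No measurement on hand bears on why the step is flat.

The compounds shown leave open whether a different group at this position, such as an amine or a longer chain like ethylsulfanyl, would move the number beyond the scatter. Going by these compounds alone, also open is whether methylsulfonyl in place of methylsulfanyl gives an equally flat step in a compound without the amino group, since this single pair in this assay is the only reading of the change so far.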